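Replacing an Aromatic Group with a Hexyl Chain

The source may hold more compounds than are shown below. What is called first, only, known or untested is meant among the compounds shown, and "the series" means these compounds.

Among the compounds with values here, in a functional assay on MDA-MB-231 cells (Homo sapiens) for antiproliferative activity, read by sulforhodamine B assay, with a stated time of 48 h (on this read-out lower numbers stand for stronger inhibition of growth and higher numbers for weaker inhibition of growth), compound 1 (`Cc1ccc(-c2cn(CCCN3C(=O)COc4ccccc43)nn2)cc1`) gives 1120 nM as the lowest of three numbers so far. Compound 2 (`CCCCCc1ccc(-c2cn(CCCN3C(=O)COc4ccccc43)nn2)cc1`) gives 5000 nM and compound 3 (`COc1ccc2cc(-c3cn(CCCN4C(=O)COc5ccccc54)nn3)ccc2c1`) shows the same number with 5000 nM as its value. Compound 4 (`CCCCCCc1cn(CCCN2C(=O)COc3ccccc32)nn1`) departs from compound 1 by a single change: hexyl in place of 4-methylphenyl on an aromatic carbon with hexyl in place of 4-methylphenyl on an aromatic carbon of a five-membered aromatic ring with 3 nitrogen. Within the data shown here, no measured compound carries hexyl there, so no step shows this change directly. Among the measured compounds shown here, the closest evidence is the one measured step, a 4.5-fold higher number from compound 1 to compound 2 (0.65 log units; beyond the scatter) which comes with butyl in place of hydrogen on a saturated chain carbon. Resting on that step and on compound 3 at 5000 nM as a second departure from compound 1, a higher number of similar size is expected for the hexyl in this assay as well. The expected change is a 3.6-fold higher number from compound 1 to compound 4 (0.55 log units; beyond the scatter) with wide uncertainty. Compound 4 is estimated at 4000 nM with an expected range from 1500 nM to 10000 nM in this estimate.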

Compound 4, concentration for 50% growth inhibition: 1100 nM
Estimate against measurement, compound 4: 3.6-fold (0.56 log units) above, outside the stated range (below it).
By their numbers in this assay, from the lowest: compounds 4 and 1 (each within the scatter of the next); then compounds 2 and 3 (each within the scatter of the next).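

In this assay, the change from the 4-methylphenyl group to hexyl gives a 1.0-fold lower number from compound 1 to compound 4 (0.01 log units; within the scatter), so at this aromatic carbon of the five-membered aromatic ring with 3 nitrogen, the six-membered aromatic ring of carbon only can give way to an open chain with no shift beyond the scatter. The one earlier step, a 4.5-fold higher number from compound 1 to compound 2 (0.65 log units; beyond the scatter), had shown only that extending the group at this place on its aromatic ring raises the number, whereas replacing the whole group with a chain of similar size does not. No measurement shown here gives a reason for either result.

On these data alone, whether a chain longer or shorter than hexyl would keep the number of compound 4 remains open. So does whether a hexyl chain ending in an amine or a carboxylic acid would keep it.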